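Series notes: chloro to hydrogen, compound 1 to compound 4

This account rests on a few compounds, and the source may have more. Where it says the series, first, only, none or still open, it means among the compounds named here.

Measured compounds:
compound 1, `CC1(C)Cc2c(OCc3ccccc3)ccc(C(=O)/C=C/c3ccc(Cl)cc3)c2O1`; in a functional assay on B16 cells (Mus musculus) for antiproliferative activity, read by MTT assay, with a stated time of 48 h (a lower number here means a stronger inhibitor, a higher number a weaker inhibitor), compound 1 gives > 100000 nM, which is a limit of the assay and not a number.
compound 2, `CC1(C)Cc2c(ccc(C(=O)/C=C/c3ccc(F)cc3)c2OCc2ccccc2)O1`; in this assay compound 2 gives > 100000 nM, again a limit.
compound 3, `COc1ccc(/C=C/C(=O)c2ccc3c(c2OCc2ccccc2)CC(C)(C)O3)cc1`; in this assay compound 3 gives > 100000 nM, again a limit.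

Compound 1 therefore stands at the limit rather than at a number, and the two other values shown are limits too, so that all three sit at the limit of > 100000 nM in this assay, at which 3 of the 3 values shown sit. Going by the values given here, the one single-point step among the measured compounds, a step that the two limits leave unreadable from compound 2 to compound 3, is unreadable because both ends are limits; it shows nothing about size or direction.

The step to be followed leads to compound 4, `CC1(C)Cc2c(OCc3ccccc3)ccc(C(=O)/C=C/c3ccccc3)c2O1`. Compared with compound 1 the change is hydrogen in place of chloro on an aromatic carbon. No measured step bears on this change, since the only step shown is unreadable. With every measured value at the limit, compound 4 is expected to remain there as well, and the step that the limit leaves unreadable from compound 1 to compound 4 is expected to be nothing readable. For compound 4 the estimate in this assay is 150000 nM, with a range from 40000 nM to 600000 nM, most likely reported only as a limit.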

Compound 4, half-maximal inhibitory concentration: 30300 nM
Compound 4: the middle estimate sits 5.0-fold (0.69 log units) above what was measured, outside the stated range (below it).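

In this assay, going by these compounds alone, taking the chloro group off the aromatic carbon, the change from 4-chlorophenyl to phenyl, gives the first readable step: an at least 3.3-fold lower number from compound 1 to compound 4 (0.51 log units; beyond the scatter). Compound 4 gives 30300 nM, so this position is the first shown to yield a measured number, and hydrogen is tolerated there where chloro is not. The other values shown give no number, and the true size of the step stays unknown: the limit of > 100000 nM in this assay, at which 3 of the 4 values shown sit.

The step between compound 2 and compound 3 cannot be read, so the fluoro and methoxy groups add nothing on this position. Going by these compounds, whether an amine, a hydroxyl or a carboxylic acid on the same aromatic carbon would hold, lower or lose the number reached by compound 4 remains open.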